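A few compounds are considered here, and "the series" means these few. Any claim that something is new, unique, unknown or untested is made for them only; others in the source may bear on it.

Working notes on the series, read in an ADME assay on HepG2 cells (Homo sapiens) for cytotoxicity, read by MTT assay, with a stated time of 48 h; on this read-out higher numbers stand for weaker inhibition and lower numbers for stronger inhibition. Compound 1 `CC(C)CN1C(=O)/C(=C/c2ccc(N(C)C)cc2)S/C1=N\c1ccccc1` gives > 100000 nM, which is a limit of the assay. Compound 2 `CC(C)CN1C(=O)/C(=C/c2ccc([N+](=O)[O-])cc2)S/C1=N\c1ccccc1` gives > 100000 nM, likewise a limit. For the measured compounds named here, the only measured step, a step that the two limits leave unreadable from compound 1 to compound 2, has no readable size. Compound 3 `CC(C)CN1C(=O)/C(=C/c2ccccc2O)S/C1=N\c1ccccc1` has no number of its own, its entry being "not determined" (no result reported), so it can be placed only by reference to the values shown for the other compounds.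

The change to compound 4 `Cc1ccsc1/C=C1\S/C(=N\c2ccccc2)N(CC(C)C)C1=O` is 3-methylthiophen-2-yl in place of 2-hydroxyphenyl on a double-bonded chain carbon bound to a double-bonded ring carbon. Going by the values given here, with two of the three values resting at the limit of > 100000 nM in this assay, at which 2 of the 3 values shown sit, no measured step offers a size to carry over to this change. Among the compounds with values here, no step of definite size or direction is therefore expected in this assay, and the assay is likely to report only a limit again. For compound 4 the expected value is 100000 nM, with an estimated range of 30000 nM to 200000 nM.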

Compound 4, half-maximal inhibitory concentration: 89200 nM
For compound 4 the middle estimate is 1.1-fold (0.05 log units) above the measured one; low and high end bracket the measured number.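

For the compounds shown here, with the 3-methylthiophen-2-yl group on the double-bonded chain carbon, compound 4 gives 89200 nM in this assay, the first reading that is a number and not a limit. Against the two substituted phenyl groups, the readings are an at least 1.1-fold lower number from compound 2 to compound 4 (0.04 log units; that floor lies within the scatter) and an at least 1.1-fold lower number from compound 1 to compound 4 (0.04 log units; that floor lies within the scatter); both are floors only, so neither establishes a real difference. Compound 1 and compound 2 remain limits of the assay: the limit of > 100000 nM in this assay, at which 2 of the 4 values shown sit.

As far as these compounds go, compound 3 has no result, so the change from 2-hydroxyphenyl to 3-methylthiophen-2-yl cannot be sized, and the true positions of compound 1 and compound 2 stay unknown. Also open, from the compounds shown here alone, is whether a furan-2-yl or a pyridin-3-yl group in the same place would give a number or another limit.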